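A few compounds are considered here, and "the series" means these few. Any claim that something is new, unique, unknown or untested is made for them only; others in the source may bear on it.

In a functional assay on KB cells (Homo sapiens) for antiproliferative activity, read by sulforhodamine B assay, with a stated time of 3 days (on this read-out lower numbers stand for an effect already at smaller amounts and higher numbers for an effect only at larger amounts of compound), compound 1 `CCC1=C(O)c2c(oc(-c3ccccc3F)cc2=O)C(CC)(CC)C1=O`, which carries a 2-fluorophenyl group, gives > 56.2 uM, and this is a limit of the assay and not a number. Within the data shown here, compound 2 `CCC1=C(O)c2c(oc(-c3ccc(C)c(C)c3)cc2=O)C(CC)(CC)C1=O`, with a 3,4-dimethylphenyl group on the same core, gives 35.5 uM, so it holds the only true number so far and has no measured partner to be ranked against.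

Compound 3 `CCC1=C(O)c2c(oc(-c3ccc(OC)c(F)c3)cc2=O)C(CC)(CC)C1=O` keeps the core and changes the same aromatic group: 3-fluoro-4-methoxyphenyl in place of 3,4-dimethylphenyl on an aromatic carbon. The exchange takes place on an aromatic carbon next to the ring oxygen.

Among the measured compounds shown here, only one measured step bears on this change, since it also swaps one substituted phenyl group for another at that carbon. That step is an at least 1.5-fold lower number from compound 1 to compound 2 (0.19 log units; that floor lies within the scatter). For the measured compounds named here, with so little to go on, and with compound 2 and an at least 1.5-fold lower number from compound 1 to compound 2 (0.19 log units; that floor lies within the scatter) as the only guide, no change beyond the scatter is expected in this assay, and no direction can be favoured. The estimate amounts to an expected 1.1-fold higher number from compound 2 to compound 3 (0.03 log units; within the scatter). For compound 3 the estimated value is 38 uM, with an expected range from 17 uM to 60 uM.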

Compound 3, concentration for half-maximal effect: 26.7 uM
Estimate against measurement, compound 3: 1.4-fold (0.15 log units) above; low and high end bracket the measured number.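

Exchanging 3,4-dimethylphenyl for 3-fluoro-4-methoxyphenyl at this aromatic carbon gives, in this assay, a 1.3-fold lower number from compound 2 to compound 3 (0.12 log units; within the scatter), so a group with one hydrogen-bond acceptor and a group with none cannot be told apart here. Among these compounds, measured against the 2-fluorophenyl group, the 3-fluoro-4-methoxyphenyl group shows an at least 2.1-fold lower number from compound 1 to compound 3 (0.32 log units; beyond the scatter), and this is the first step at this carbon to pass beyond the scatter. That step is only a floor, not a full size, since the value of compound 1 is a limit of the assay and not a number: the limit of > 56.2 uM in this assay, at which 1 of the 3 values shown sits.

Fluorine and methoxy enter together in compound 3, so the share of each remains open, and 3-fluorophenyl or 4-methoxyphenyl alone at this carbon would separate them. Also open, from the compounds shown here alone, is whether a group of another kind, such as an amine, a carboxylic acid or a longer alkyl chain in place of the substituted phenyl, would move the number beyond the scatter from the values of compound 2 and compound 3.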